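Adding a Phenylsulfonyl Group to the Amine of Compound 1

This account rests on a few compounds, and the source may have more. Where it says the series, first, only, none or still open, it means among the compounds named here.

Compound 1 `CCCCc1ccc(CNCc2ccccc2)c(=O)n1Cc1ccc(-c2ccccc2-c2nn[nH]n2)cc1` gives 1 nM in a functional assay (aorta) for antagonist activity, with Oryctolagus cuniculus as the target (on this read-out lower numbers stand for stronger inhibition and higher numbers for weaker inhibition), the lowest of the three measured numbers. Compound 3 `CCCCc1ccc(CNC(C)=O)c(=O)n1Cc1ccc(-c2ccccc2-c2nn[nH]n2)cc1` gives 3 nM, and compound 2 `CCCCc1ccc(CNC(=O)NC2CCCCC2)c(=O)n1Cc1ccc(-c2ccccc2-c2nn[nH]n2)cc1` gives 90 nM. The measured steps are a 3.0-fold higher number from compound 1 to compound 3 (0.48 log units; beyond the scatter) and a 90-fold higher number from compound 1 to compound 2 (1.95 log units; beyond the scatter); both exchanged the benzyl group on the amine nitrogen, and both weakened inhibition, one modestly and one strongly. Compound 4 `CCCCc1ccc(CN(Cc2ccccc2)S(=O)(=O)c2ccccc2)c(=O)n1Cc1ccc(-c2ccccc2-c2nn[nH]n2)cc1` keeps the benzyl and instead carries phenylsulfonyl in place of hydrogen on an amine nitrogen. Among the compounds with values here, no measured step matches this change, so the two steps only show that this nitrogen tolerates alteration poorly. A weakening beyond the scatter is therefore expected, a 30-fold higher number from compound 1 to compound 4 (1.48 log units; beyond the scatter). Compound 4 is expected to give 30 nM, within 5 nM to 200 nM.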

Compound 4, half-maximal inhibitory concentration: 20 nM
For compound 4 the middle estimate is 1.5-fold (0.18 log units) above the measured one, within the range that was stated.
By their numbers in this assay, from the lowest: compound 1; then compound 3; then compound 4; then compound 2.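

In this assay, placing phenylsulfonyl on the amine nitrogen of compound 1 gives a 20-fold higher number from compound 1 to compound 4 (1.30 log units; beyond the scatter). The earlier steps shown here exchanged the benzyl group, whereas this one keeps it and replaces only the hydrogen, so a large loss also occurs with the benzyl group still in place. Nothing measured here accounts for the size of this step.

The compounds shown leave open whether the loss follows from removing that hydrogen or from the phenylsulfonyl group itself. A methyl or methylsulfonyl group on the same nitrogen would help separate the two.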